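From compound 2 to compound 4: a chain on nitrogen

The compounds below may be only part of what the source reports. "The series", "measured", "known", "first", "only" and "open" are said of these compounds alone.

Measured values in an ADME assay on MT4 cells (Homo sapiens) for cytotoxicity, read by MTT assay, with a stated time of 96 h (a lower number here means that less compound is tolerated, a higher number that more compound is tolerated), are as follows.
Compound 1 `CN(C)CCCN(/N=N/c1c(F)cccc1F)c1ccccc1` gives 23000 nM
Compound 2 `Fc1ccc(F)c(/N=N/Nc2ccccc2)c1` gives 100000 nM
Compound 3 `Fc1ccc(F)c(/N=N/Nc2cccc(C(F)(F)F)c2)c1` gives > 100000 nM as a limit

Of the two actual numbers, compound 2 holds the higher (100000 nM), and compound 1 lies lower (23000 nM) by a gap beyond the scatter. Compound 3 has only a limit (> 100000 nM).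

Compound 4 `CN(C)CCCN(/N=N/c1cc(F)ccc1F)c1ccccc1` keeps the core of compound 2 and takes 3-(dimethylamino)propyl in place of hydrogen on a nitrogen on an aromatic ring. Among the compounds with values here, the one measured step, a number no lower from compound 2 to compound 3 (the limit leaves the size open), is a different change, and its size cannot be read, so it gives little guidance here. Within the data shown here, the better guide is compound 1 (23000 nM), which carries the same chain on a closely related core, though no measured step isolates that chain. A lower number in this assay, beyond the scatter, is therefore expected, an estimated 4.0-fold lower number from compound 2 to compound 4 (0.60 log units; beyond the scatter) here. Compound 4 is expected to give about 25000 nM (estimated range 9000 nM to 60000 nM).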

Compound 4, half-maximal cytotoxic concentration: 13000 nM
Compound 4: the middle estimate sits 1.9-fold (0.28 log units) above what was measured, and the stated range covers the measured number.
By their numbers in this assay, from the lowest: compounds 4 and 1 (each within the scatter of the next); then compound 2.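

In this assay, the nitrogen on an aromatic ring turns out to be a position where substitution registers: 3-(dimethylamino)propyl in place of hydrogen gives a 7.7-fold lower number from compound 2 to compound 4 (0.89 log units; beyond the scatter). Within the data shown here, this is the first step with a readable size and the first to isolate this chain, as the only earlier step, on trifluoromethyl, cannot be read. That reading has an upper edge, since the series reaches the top of the assay's range with compound 3, whose value is only a limit: the limit of > 100000 nM in this assay, at which 1 of the 4 values shown sits.

As far as these compounds go, whether the lower number follows from the length of the chain or from its terminal dimethylamino group stays open. A plain propyl chain, a longer chain ending in the same amine, or a chain ending in a carboxylic acid would separate those two readings.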